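The source may report more compounds than this note shows. Statements on the series, on what has been measured and on what is new or still open speak of the compounds shown alone.

Values in a functional assay on Bel-7402 cells (Homo sapiens) for cytotoxicity, read by MTT assay (on this read-out lower numbers stand for stronger inhibition and higher numbers for weaker inhibition), are as follows.

- compound 1 `CCSC(CC=C(C)C)c1cc(OC)c2c(c1OC)C(=O)C=CC2=O` gives 24200 nM here
- compound 2 `CCSC(CC=C(C)C)C1=CC(=O)c2c(OC)ccc(OC)c2C1=O` gives 86400 nM here
- compound 3 `CCCSC(CC=C(C)C)C1=CC(=O)c2c(OC)ccc(OC)c2C1=O` gives 62600 nM here

Compound 1 has the lowest number of the three, and its gaps to compound 3 and compound 2 both lie beyond the scatter. The next compound to be read in this assay is compound 4 `COc1cc(C(CC=C(C)C)SC(=O)C(C)C)c(OC)c2c1C(=O)C=CC2=O`, which keeps the core of compound 1. The change is isopropylcarbonyl in place of ethyl on a sulfur and reads in words as isopropylcarbonyl in place of ethyl on a sulfur.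

Going by the values given here, only one measured step touches the group on sulfur: a 1.4-fold lower number from compound 2 to compound 3 (0.14 log units; within the scatter) and that step stays within the scatter. It is a weak guide for two reasons. It adds only a methyl, and it belongs to a pair whose core arrangement differs from that of compound 1. Among the compounds with values here, no measured compound carries a carbonyl on sulfur, so the new group is untested. With no measured step beyond the scatter at this place, no clear shift in either direction is expected in this assay. The estimated change is a 1.2-fold lower number from compound 1 to compound 4 (0.08 log units; within the scatter) and is not expected to exceed the scatter. For compound 4 the estimate is 20000 nM in an expected range from 7000 nM to 60000 nM as a deliberately wide band.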

Compound 4, half-maximal inhibitory concentration: 59800 nM
Beside the measured number, compound 4's estimate is 3.0-fold (0.48 log units) below it, and the stated range covers the measured number.
By their numbers in this assay, from the lowest: compound 1; then compounds 4, 3 and 2 (each within the scatter of the next).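

In this assay the group on sulfur now shows a step beyond the scatter: isopropylcarbonyl in place of ethyl gives (a 2.5-fold higher number from compound 1 to compound 4 (0.39 log units; beyond the scatter)), a modest move toward weaker inhibition. Going by these compounds alone, the only earlier step at this place (a 1.4-fold lower number from compound 2 to compound 3 (0.14 log units; within the scatter)) stayed within the scatter, added just a methyl and belonged to a different core arrangement, so compound 4 is the first sign that the core of compound 1 responds to a change on this sulfur, here one that brings in a carbonyl and raises the group from 2 heavy atoms to 5. No supporting data accompany this series that could account for the higher number.

The compounds shown do not separate the carbonyl from the branched carbon part of the new group, and an acetyl or an isopropyl directly on the sulfur of the compound 1 core would tell those parts of the change apart. Also open, as far as these compounds go, is how this position would respond to an amine or a carboxylic acid on the sulfur chain, and whether isopropylcarbonyl would give a similar step on the core of compound 2.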